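Triazole nitrogen substituent: benzyl in place of 4-ethylphenyl

The source may hold more compounds than are shown below. What is called first, only, known or untested is meant among the compounds shown, and "the series" means these compounds.

Two compounds of the series have numbers in an in vitro assay on LLC-PK1 cells for displacement of a labelled ligand from growth hormone secretagogue receptor type 1 (Homo sapiens); on this read-out lower numbers stand for stronger inhibition and higher numbers for weaker inhibition. Compound 1 `CCc1ccc(-n2c(CCc3c[nH]c4ccccc34)nnc2[C@H](NC(=O)c2ccccn2)c2c[nH]c3ccccc23)cc1` gives 49 nM. Compound 2 `CCc1ccc(-n2c(CCc3c[nH]c4ccccc34)nnc2[C@H](NC(=O)Cc2ccccn2)c2c[nH]c3ccccc23)cc1` gives 96 nM. Among the measured compounds shown here, the only measured step, a 2.0-fold higher number from compound 1 to compound 2 (0.29 log units; within the scatter), concerns the group on the carbonyl carbon and stays within the scatter. On the numbers shown compound 2 has the higher of the two, its gap to compound 1 being within the scatter, so the two are not separated.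

Compound 3 `O=C(Cc1ccccn1)N[C@H](c1c[nH]c2ccccc12)c1nnc(CCc2c[nH]c3ccccc23)n1Cc1ccccc1` keeps the amide of compound 2 and differs elsewhere: benzyl in place of 4-ethylphenyl on an aromatic nitrogen. For the measured compounds named here, no measured step touches the group on the aromatic nitrogen; the step from compound 1 to compound 2 concerns the carbonyl side only and does not bear on the present change. Going by the values given here, with no precedent, neither the direction nor the size of the change can be read from the data. Compound 3 is therefore expected near compound 2, with a wide range: 140 nM, between 40 nM and 500 nM. The estimate implies the step of a 1.5-fold higher number from compound 2 to compound 3 (0.16 log units; within the scatter), expected to remain within the scatter.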

Compound 3, half-maximal inhibitory concentration: 61 nM
The estimate for compound 3 lay 2.3-fold (0.36 log units) above the measured number, within the range that was stated.
By their numbers in this assay, from the lowest: compounds 1, 3 and 2 (each within the scatter of the next).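

In this assay, the group on the aromatic nitrogen now has its first measured step, a 1.6-fold lower number from compound 2 to compound 3 (0.20 log units; within the scatter), and this step stays within the scatter, so benzyl and 4-ethylphenyl are not separated at this position. Taking out 4-ethylphenyl and putting in benzyl keeps one six-membered aromatic ring of carbon only and goes from 8 heavy atoms to 7, and on these numbers that exchange leaves the read-out unresolved, although this holds so far only for the amide bearing the (pyridin-2-yl)methyl group. No measurement at hand accounts for this result.

The compounds shown leave open whether the same exchange would also stay within the scatter on the pyridin-2-yl amide of compound 1, where the two groups on the aromatic nitrogen have no matched pair. They also leave open whether a longer chain such as 2-phenylethyl on that nitrogen, or an amine or a carboxylic acid on the benzyl ring, would give a step beyond the scatter.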